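Swapping Nitro for Methyl on a Sulfonamide Chalcone

This account rests on a few compounds, and the source may have more. Where it says the series, first, only, none or still open, it means among the compounds named here.

Compound 1: `Cc1ccc(S(=O)(=O)Nc2ccc(C(=O)/C=C/c3ccc([N+](=O)[O-])cc3)cc2)cc1` — 26000 nM
Compound 2: `C/C(=N\NC(=O)c1sc(N)c(C#N)c1N)c1ccc(NS(=O)(=O)c2ccc(C)cc2)cc1` — 21800 nM
Compound 3: `C/C(=N\NC(=O)CC#N)c1ccc(NS(=O)(=O)c2ccccc2)cc1` — 28000 nM

Three compounds built around the same sulfonamide-bearing core were tested in a functional assay on HepG2 cells (Homo sapiens) for cytotoxicity, read by sulforhodamine B assay, with a stated time of 48 h; on this read-out higher numbers stand for weaker inhibition and lower numbers for stronger inhibition. In this assay compound 1 gives 26000 nM. Compound 2 gives 21800 nM, and compound 3 gives 28000 nM. Compound 1 sits second highest of the three numbers, but its nearest neighbour, compound 3, and its furthest neighbour, compound 2, both lie within the usual scatter of repeated measurements, so none of the three can be ranked against the others with any confidence; the set reads as a cluster at one level.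

Compound 4, `Cc1ccc(/C=C/C(=O)c2ccc(NS(=O)(=O)c3ccc(C)cc3)cc2)cc1`, has not yet been measured. It differs from compound 1 in a single place: methyl in place of nitro on an aromatic carbon. Among the measured compounds shown here, no pair of measured compounds shows this same change, so its size has not been observed here. With all three measured numbers lying close together and nothing to suggest a large effect, the expected step from compound 1 to compound 4 in this assay is small, with no clear direction and probably not beyond the scatter. Compound 4 is therefore estimated at 30000 nM, with a plausible range from 10000 nM to 90000 nM. That estimate corresponds to a step of a 1.2-fold higher number from compound 1 to compound 4 (0.06 log units; within the scatter), expected to be within the scatter.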

Compound 4, half-maximal inhibitory concentration: 49800 nM
Compound 4: the middle estimate sits 1.7-fold (0.22 log units) below what was measured; low and high end bracket the measured number.
By their numbers in this assay, from the lowest: compounds 2, 1, 3 and 4 (each within the scatter of the next, the first and the last beyond it).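

The change from 4-nitrophenyl to 4-methylphenyl, not seen in any earlier pair, gives a 1.9-fold higher number from compound 1 to compound 4 (0.28 log units; within the scatter) in this assay, so this one swap on an aromatic carbon, para to a large group, stays within the scatter. The group that leaves has three heavy atoms and two hydrogen-bond acceptors, while the group that enters has one heavy atom and no hydrogen-bond acceptors, so in this pair even that difference in make-up does not give a step that can be told apart from repeat-to-repeat variation. No measurement here explains the size or direction of this step, and the reading stands as an observation only.

From the compounds shown here alone, what remains open is whether a different group on the same aromatic carbon, such as an amine, a carboxylic acid or a methoxy group, would move the number beyond the scatter. Among the compounds shown here, it is also open whether the swap from nitro to methyl would give a similar step on another core, since this single pair is the only view of the change.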